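Cytotoxicity of a benzoxaborole series: a phenethyl ketone

The source may hold more compounds than are shown below. What is called first, only, known or untested is meant among the compounds shown, and "the series" means these compounds.

Compound 1, `OB1OCc2ccc(-n3cc(Sc4ccccc4O)c4ccccc43)cc21`, gives > 10 ug/mL in an ADME assay on L929 cells (Mus musculus) for cytotoxicity, read by resazurin assay, with a stated time of 72 h (a higher number here means a weaker inhibitor, a lower number a stronger inhibitor), a limit of the assay.
Compound 2, `O=C(c1cccc(Cl)c1)c1ccn(-c2ccc3c(c2)B(O)OC3)c1`, gives > 10 ug/mL in this assay, again a limit and not a number.

Both measured compounds therefore sit at the same place, as the limit of > 10 ug/mL in this assay, at which 2 of the 2 values shown sit, records. Compound 2 stands at that limit, so its true half-maximal inhibitory concentration is not resolved.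

Compound 3, `O=C(CCc1ccccc1)c1ccn(-c2ccc3c(c2)B(O)OC3)c1`, carries phenethyl in place of 3-chlorophenyl on a carbonyl carbon. No step between measured compounds is available to calibrate this change, so nothing in the shown data points in either direction. The account expects the step that the limit leaves unreadable from compound 2 to compound 3 to be none beyond the scatter, and expects compound 3 again to fall at the limit of this assay. Compound 3 is estimated at 15 ug/mL, with a range from 7 ug/mL to 40 ug/mL, because compound 2 gives > 10 ug/mL.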

Compound 3, half-maximal inhibitory concentration: > 10 ug/mL
Compound 3: a limit, no number; the forecaster's own chance of this, stated with the estimate: 85%; the middle value does not contradict the limit.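

Compound 3 gives > 10 ug/mL in this assay, a limit and not a number. For the compounds shown here, no step from compound 2 to compound 3 can be read, as both rest on the same limit: the limit of > 10 ug/mL in this assay, at which 3 of the 3 values shown sit. The compounds shown leave open where the true half-maximal inhibitory concentration of each lies, and whether phenethyl in place of 3-chlorophenyl on a carbonyl carbon changes it at all.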